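The source may hold more compounds than are shown below. What is called first, only, known or untested is meant among the compounds shown, and "the series" means these compounds.

Measured so far, in a functional assay on A549 cells (Homo sapiens) for cytotoxicity, read by MTT assay, with a stated time of 48 h; a lower number here means a stronger inhibitor, a higher number a weaker inhibitor:
Compound 1, `COc1ccc(CN(C(=O)Nc2ccc(Cl)cc2)n2cnnc2)cc1OC`: 44200 nM
Compound 2, `N#Cc1ccc(CN(C(=O)Nc2cc(C(F)(F)F)cc(C(F)(F)F)c2)n2cnnc2)cc1`: 9390 nM
Compound 3, `CCCCCCCCCNC(=O)N(Cc1cc(OC)ccc1OC)n1cnnc1`: a limit of the assay, > 50000 nM

Among the numbers given, compound 2 has the lowest; compound 1 sits a good way higher, beyond the usual scatter. The value of compound 3 is a limit, not a number, and sits at the limit of > 50000 nM in this assay, at which 1 of the 3 values shown sits.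

Compound 4, `COc1ccc(CN(C(=O)Nc2cc(C(F)(F)F)cc(C(F)(F)F)c2)n2cnnc2)cc1OC`, differs from compound 2 in one place: 3,4-dimethoxyphenyl in place of 4-cyanophenyl on a saturated chain carbon bound to an amide-type nitrogen. Among the measured compounds shown here, no measured pair shows this change directly, so the size of the step can only be expected, not read off. Since compound 1, which also carries a 3,4-dimethoxybenzyl group, gives 44200 nM, the expectation is that the number rises from compound 2 to compound 4, a step estimated at a 2.3-fold higher number from compound 2 to compound 4 (0.37 log units; beyond the scatter). Compound 4 is accordingly expected to give about 22000 nM, with a likely range from 8000 nM to 50000 nM.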

Compound 4, half-maximal inhibitory concentration: 16200 nM
Compound 4: the middle estimate sits 1.4-fold (0.13 log units) above what was measured; low and high end bracket the measured number.
By their numbers in this assay, from the lowest: compounds 2 and 4 (each within the scatter of the next); then compound 1. At a limit, above all of these: compound 3.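

In this assay, the step from 4-cyanophenyl to 3,4-dimethoxyphenyl on a saturated chain carbon bound to an amide-type nitrogen is a 1.7-fold higher number from compound 2 to compound 4 (0.24 log units; within the scatter), so the two groups cannot be told apart here. Compound 1 carries the same 3,4-dimethoxyphenyl group and gives 44200 nM, whereas compound 4 gives 16200 nM, so that group alone does not fix a number near compound 1's. Nothing measured here bears on why the two groups match. Still open, from the compounds shown here alone, is whether a phenyl carrying an amine or a carboxylic acid at this place would give a step beyond the scatter.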